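Bromo substitution on the phenyl ring of compound 3

A few compounds are considered here, and "the series" means these few. Any claim that something is new, unique, unknown or untested is made for them only; others in the source may bear on it.

Measured compounds in a functional assay on HEp-2 cells (Homo sapiens) for cytotoxicity, read by sulforhodamine B assay, with a stated time of 48 h; a lower number here means a stronger inhibitor, a higher number a weaker inhibitor:
compound 1, `CC(=O)N1N=C(c2ccco2)CC1c1cccc(O)c1`: 10000 nM
compound 2, `CC(=O)N1N=C(c2cccc3ccccc23)CC1c1ccco1`: 17000 nM
compound 3, `O=CCN1N=C(c2ccc3ccccc3c2)CC1c1ccccc1`: 8400 nM

Compound 3 holds the lowest of the three numbers. Its nearest neighbour is compound 1, whose number lies within the scatter of that of compound 3; compound 2 is the furthest, its number beyond the scatter. Nothing in this set of three separates the effect of any single structural feature, as no two of them differ in one place only.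

Compound 4, `O=CCN1N=C(c2ccc3ccccc3c2)CC1c1cccc(Br)c1`, differs from compound 3 in one place: bromo in place of hydrogen on an aromatic carbon. Within the data shown here, no measured pair shows what this exchange does in this assay. The expectation is a step of modest size, toward a lower number, though a step within the scatter would not surprise. For compound 4 the estimated value in this assay is 5000 nM, with a range from 2000 nM to 15000 nM. This estimate corresponds to an expected step of a 1.7-fold lower number from compound 3 to compound 4 (0.23 log units; within the scatter).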

Compound 4, half-maximal inhibitory concentration: 8780 nM
Beside the measured number, compound 4's estimate is 1.8-fold (0.24 log units) below it, and the stated range covers the measured number.
By their numbers in this assay, from the lowest: compounds 3, 4, 1 and 2 (each within the scatter of the next, the first and the last beyond it).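

In this assay, among these compounds, the exchange of phenyl for 3-bromophenyl gives a 1.0-fold higher number from compound 3 to compound 4 (0.02 log units; within the scatter) and provides the first comparison of compounds that differ in one place. At this position on the six-membered aromatic ring, a bromo group in place of hydrogen therefore leaves the cytotoxicity read-out within the scatter, so the two compounds cannot be ordered. No supporting data bear on why this exchange gives so small a step.

On these data alone, whether the same holds for a bromo group elsewhere on this ring remains open, since only this one place is covered. Also open, as far as these compounds go, is whether a hydroxyl, an amine or a carboxylic acid at this place would give a step beyond the scatter.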